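The source may hold more compounds than are shown below. What is called first, only, known or untested is meant among the compounds shown, and "the series" means these compounds.

Compound 1 `Oc1nc2nonc2nc1Nc1ccccc1F`: 12500 nM
Compound 2 `CCCCc1ccc(Nc2nc3nonc3nc2O)cc1`: 2100 nM
Compound 3 `CCc1ccc(Nc2nc3nonc3nc2O)c(F)c1`: 6700 nM

In an assay on mitochondria from L6 cells (Rattus norvegicus) for activation, with a stated time of 90 min (on this read-out lower numbers stand for an effect already at smaller amounts and higher numbers for an effect only at larger amounts of compound), compound 3 has the second highest of the three numbers; compound 1 is nearest to it and compound 2 furthest. Compound 4 `CCCCc1ccc(Nc2nc3nonc3nc2O)c(F)c1` differs from compound 3 by ethyl in place of hydrogen on a saturated chain carbon, two bonds along the chain from an aromatic carbon. Going by the values given here, the only measured step of a related kind is a 1.9-fold lower number from compound 1 to compound 3 (0.27 log units; within the scatter), which stays within the scatter. Among the compounds with values here, compound 2, which carries butyl where compound 3 carries ethyl together with a fluorine, shows a clearly lower number than compound 3, although these two differ in two places and no single step joins them. A moderate decrease is therefore expected, a 2.2-fold lower number from compound 3 to compound 4 (0.35 log units; beyond the scatter). Compound 4 is estimated at 3000 nM, within a range of 1200 nM to 7500 nM.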

Compound 4, half-maximal effective concentration: 1100 nM
For compound 4 the middle estimate is 2.7-fold (0.44 log units) above the measured one; the whole stated range lies above it.
By their numbers in this assay, from the lowest: compounds 4 and 2 (each within the scatter of the next); then compounds 3 and 1 (each within the scatter of the next).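

In this assay, going from ethyl to butyl on the fluorine-bearing compounds gives a clear change (a 6.1-fold lower number from compound 3 to compound 4 (0.78 log units; beyond the scatter)), so at this chain position, added length counts for more than the earlier within-scatter step suggested. Fluoro in place of hydrogen, by contrast, stays within the scatter (a 1.9-fold lower number from compound 2 to compound 4 (0.28 log units; within the scatter)), while the largest of these steps is the one that brings in butyl (an 11-fold lower number from compound 1 to compound 4 (1.06 log units; beyond the scatter)). Nothing measured here offers a cause for these steps. From the compounds shown here alone, whether a longer chain such as hexyl would lower the number further remains open. So does whether a branched chain or a chain ending in an amine would match butyl.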